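Deoxygenation of the sugar on a brominated benzyl purine

The source may hold more compounds than are shown below. What is called first, only, known or untested is meant among the compounds shown, and "the series" means these compounds.

Three measured compounds share a core that carries an acetamido group and a substituted benzyl ether; they differ in the ring on the aromatic nitrogen and in the halogen on the benzyl ring. In a functional assay on M4Beu cells for cytotoxicity against M4Beu cell line (Homo sapiens), in the presence of a further agent that is not named here (on this read-out lower numbers stand for an effect already at smaller amounts and higher numbers for an effect only at larger amounts of compound), compound 1 `CC(=O)Nc1nc(OCc2ccccc2)c2ncn(C3CC(O)C(O)O3)c2n1` gives 165 uM. In this assay compound 2 `CC(=O)Nc1nc(OCc2ccc(I)cc2)c2ncn(C3O[C@H](O)[C@@H](O)[C@H]3O)c2n1` gives 82 uM. Compound 3 `CC(=O)Nc1nc(OCc2ccc(Br)cc2)c2ncn([C@H]3O[C@H](O)[C@@H](O)[C@H]3O)c2n1` gives only a limit of the assay in this assay, > 400 uM, and so stands at the weak end of what is shown, as described by the limit of > 400 uM in this assay, at which 1 of the 3 values shown sits.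

Compound 4 `CC(=O)Nc1nc(OCc2ccc(Br)cc2)c2ncn([C@H]3C[C@H](O)[C@@H](O)O3)c2n1` differs from compound 3 in one place: 4,5-dihydroxyoxolan-2-yl in place of 3,4,5-trihydroxyoxolan-2-yl on an aromatic nitrogen. Among the compounds with values here, no measured pair shows this change on its own; compound 1 carries the dihydroxy ring but also a different benzyl group. Because compound 3 is known only as a limit, the size of the step cannot be fixed, and a move within the scatter or a modest gain toward the region of compound 1 both seem possible. For compound 4 a value of about 250 uM is expected, within 90 uM to 500 uM, meaning an estimated step of an at least 1.6-fold lower number from compound 3 to compound 4 (0.20 log units; that floor lies within the scatter) in this assay.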

Compound 4, concentration for half-maximal effect: 211 uM
Beside the measured number, compound 4's estimate is 1.2-fold (0.07 log units) above it; the measured number falls inside the stated range.
By their numbers in this assay, from the lowest: compounds 2, 1 and 4 (each within the scatter of the next, the first and the last beyond it). At a limit, above all of these: compound 3.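

With the brominated benzyl group held constant, the change to 4,5-dihydroxyoxolan-2-yl from 3,4,5-trihydroxyoxolan-2-yl on an aromatic nitrogen can now be read on its own, and in this assay it gives an at least 1.8-fold lower number from compound 3 to compound 4 (0.27 log units; that floor lies within the scatter) and so yields a measured number where the trihydroxy ring gave none. On these data alone, the true size of this step stays unknown because compound 3 is known only as a limit of the assay: the limit of > 400 uM in this assay, at which 1 of the 4 values shown sits. The printed floor lies within the scatter, so these two compounds alone do not establish that the change matters.

As far as these compounds go, whether the same change would act alike with the iodinated benzyl group of compound 2 remains open. Also open, from the compounds shown here alone, is what an aminomethyl group or a carboxylic acid on the ring, or a propyl chain in its place, would do.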